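Replacing the fluoro group of compound 3 with hydrogen

A few compounds are considered here, and "the series" means these few. Any claim that something is new, unique, unknown or untested is made for them only; others in the source may bear on it.

Compound 1 `CCCCCC(CCO)n1cnc2c(Cl)ncnc21`: > 50000 nM (a limit of the assay, not a number)
Compound 2 `CCCCCCC(CCO)n1cnc2c(Cl)ncnc21`: 11900 nM
Compound 3 `CCCCCCCC(CCO)n1cnc2c(Cl)nc(F)nc21`: 17600 nM

All three were tested in a functional assay on HCT-116 cells (Homo sapiens) for antiproliferative activity, read by MTT assay, with a stated time of 48 h; on this read-out lower numbers stand for stronger inhibition and higher numbers for weaker inhibition. Compound 3 stands within the scatter of compound 2, so the two cannot be ranked. Compound 4 `CCCCCCCC(CCO)n1cnc2c(Cl)ncnc21` differs from compound 3 in one place (hydrogen in place of fluoro on an aromatic carbon): hydrogen in place of fluoro on an aromatic carbon, between two ring nitrogen atoms.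

For the measured compounds named here, no measured step touches that place. The only one available, an at least 4.2-fold lower number from compound 1 to compound 2 (0.62 log units; beyond the scatter), is methyl in place of hydrogen on a saturated chain carbon, and it bears on this change only loosely. Its size therefore sets no expectation for the aromatic carbon, and no step beyond the scatter is expected in this assay, in either direction. The expected change is a 1.5-fold lower number from compound 3 to compound 4 (0.17 log units; within the scatter), an estimate that stays within the scatter. Compound 4 is estimated at 12000 nM, with an expected range from 5000 nM to 30000 nM.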

Compound 4, half-maximal inhibitory concentration: 4160 nM
Estimate against measurement, compound 4: 2.9-fold (0.46 log units) above, and the stated range ends above it.
By their numbers in this assay, from the lowest: compound 4; then compounds 2 and 3 (each within the scatter of the next). At a limit, above all of these: compound 1.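

In this assay, for the compounds shown here, the aromatic carbon between two ring nitrogen atoms now proves to matter: hydrogen in place of fluoro gives a 4.2-fold lower number from compound 3 to compound 4 (0.63 log units; beyond the scatter) and is the first measured change at this place. With hydrogen on that carbon, the chain steps point the same way, with a 2.9-fold lower number from compound 2 to compound 4 (0.46 log units; beyond the scatter) for the added methyl and an at least 12-fold lower number from compound 1 to compound 4 (1.07 log units; beyond the scatter) for the added ethyl, and none of these three compounds goes against that trend. The last of these steps rests on a limit for compound 1, not on a number: the limit of > 50000 nM in this assay, at which 1 of the 4 values shown sits.

From the compounds shown here alone, whether a longer chain would lower the number further remains open. So does whether an amine or a methoxy group on that aromatic carbon would behave like hydrogen or like fluoro.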